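Benzyloxy in place of difluorobenzyloxy on the shared core

The source may hold more compounds than are shown below. What is called first, only, known or untested is meant among the compounds shown, and "the series" means these compounds.

Measured compounds:
Compound 1, `O=C(O)c1cccc(C2=C(c3cc(Br)ccc3OCc3ccc(F)cc3F)CCC2)c1`: in an assay on isolated protein for inhibition of prostaglandin E2 receptor EP3 subtype (Homo sapiens) (on this read-out lower numbers stand for stronger inhibition and higher numbers for weaker inhibition), compound 1 gives a limit, < 3170 nM.
Compound 2, `CSc1ccc(OCc2ccc(F)cc2F)c(C2=C(c3cccc(C(=O)O)c3)CCC2)c1`: in this assay compound 2 gives a limit, < 3170 nM.
Compound 3, `CSc1ccc(OCc2ccc(F)cc2)c(C2=C(c3cccc(C(=O)O)c3)CCC2)c1`: in this assay compound 3 gives a limit, < 3170 nM.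

Compound 1 stands only at a limit; no number is known for it. The change to compound 4, `O=C(O)c1cccc(C2=C(c3cc(Br)ccc3OCc3ccccc3)CCC2)c1`, is phenyl in place of 2,4-difluorophenyl on a saturated chain carbon bound to an oxygen on an aromatic ring. The measured steps, a step that the two limits leave unreadable from compound 1 to compound 2 and a step that the two limits leave unreadable from compound 2 to compound 3, are unreadable because of the limit of < 3170 nM in this assay, at which 3 of the 3 values shown sit. Neither step touches the benzyloxy part, so none of them bears on this change. These data give no direction and no size; a step of no readable size beyond the scatter is expected, a step that the limit leaves unreadable from compound 1 to compound 4, and compound 4 is then likely to come back as a limit again. Compound 4 is estimated at 700 nM, within 60 nM to 4000 nM.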

Compound 4, half-maximal inhibitory concentration: < 3170 nM
Compound 4: only a limit was reported; the forecaster's own chance of this, stated with the estimate: 65%; the middle value does not contradict the limit.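

No step can be read between compound 1 and compound 4, as each stands only at a limit: the limit of < 3170 nM in this assay, at which 4 of the 4 values shown sit.

In this assay the compounds shown leave open the true potency of each compound and the size of every change on the shared core.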